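The source may hold more compounds than are shown below. What is called first, only, known or untested is meant among the compounds shown, and "the series" means these compounds.

Compound 1 `CCN(CC)C(=O)[C@@H]1CCCN(S(=O)(=O)c2ccc(S(=O)(=O)N(CC)CC)cc2)C1`: in a functional assay on MIA PaCa-2 cells (Homo sapiens) for inhibition, read by MTT assay, with a stated time of 7 days (a lower number here means a stronger inhibitor, a higher number a weaker inhibitor), compound 1 gives 6400 nM.
Compound 2 `CCN(CC)S(=O)(=O)c1ccc(S(=O)(=O)N2CCC[C@@H](C(=O)NC3CN(S(C)(=O)=O)C3)C2)cc1`: in this assay compound 2 gives 2500 nM.

Compound 2 holds the lower of the two numbers, separated from compound 1 by a 2.6-fold lower number from compound 1 to compound 2 (0.41 log units; beyond the scatter). Compound 3 `CCN(CC)S(=O)(=O)c1ccc(S(=O)(=O)N2CCC[C@@H](c3nc(C)no3)C2)cc1` differs from compound 2 by 3-methyl-1,2,4-oxadiazol-5-yl in place of (1-(methylsulfonyl)azetidin-3-yl)carbamoyl on a saturated ring carbon. Among the compounds with values here, only the step from compound 1 to compound 2 touches this ring carbon, and it merely swapped one substituent of the carbonyl for another, a modest effect; no measured step removes the carbonyl altogether. She therefore expects a step of a 1.5-fold higher number from compound 2 to compound 3 (0.18 log units; within the scatter), near the scatter and, if anything, toward a higher number. Her estimate for compound 3 is 3800 nM, within 1300 nM to 11000 nM.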

Compound 3, half-maximal inhibitory concentration: 4100 nM
Compound 3: middle estimate off by 1.1-fold (0.03 log units), on the low side; measured number inside the range.
By their numbers in this assay, from the lowest: compounds 2, 3 and 1 (each within the scatter of the next, the first and the last beyond it).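

In this assay, the amide at this saturated ring carbon can give way to a five-membered aromatic ring: 3-methyl-1,2,4-oxadiazol-5-yl brings a 1.6-fold higher number from compound 2 to compound 3 (0.21 log units; within the scatter) when it replaces (1-(methylsulfonyl)azetidin-3-yl)carbamoyl and a 1.6-fold lower number from compound 1 to compound 3 (0.19 log units; within the scatter) when it replaces diethylcarbamoyl. Compound 3 thus stands within the scatter of both amides, although those two lie beyond the scatter of each other. Nothing available explains this tolerance. On these data alone, whether a carboxylic acid or a primary amine on this ring carbon would fit equally well stays open, as does the effect of a longer chain in place of the methyl on the oxadiazole.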